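Capping the ring amine of compound 2 with methylsulfamoyl

The source may report more compounds than this note shows. Statements on the series, on what has been measured and on what is new or still open speak of the compounds shown alone.

Compound 1 `O=C1CCC(CCN2CC(N3CCNCC3)C2)(c2ccc(Cl)c(Cl)c2)CN1Cc1ccccc1`: 5.01 nM
Compound 2 `O=C1CCC(CCN2CC(N3CCNCC3)C2)(c2ccc(Cl)c(Cl)c2)CN1CC1CC1`: 12.6 nM

Of the compounds shown here, two have been measured in an assay on isolated protein (artery, Oryctolagus cuniculus) with Substance-P receptor (Homo sapiens) as the target; on this read-out lower numbers stand for tighter binding and higher numbers for weaker binding. Going by the values given here, compound 1 gives 5.01 nM, and compound 2 gives 12.6 nM; the single step between them, a 2.5-fold higher number from compound 1 to compound 2 (0.40 log units; beyond the scatter), is modest but beyond the scatter. Among the compounds with values here, compound 2 therefore stands at the higher of the two numbers, with compound 1 as its only neighbour.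

Compound 3 `CNS(=O)(=O)N1CCN(C2CN(CCC3(c4ccc(Cl)c(Cl)c4)CCC(=O)N(CC4CC4)C3)C2)CC1` keeps the whole of compound 2 and changes only one point: methylsulfamoyl in place of hydrogen on an amine nitrogen in a ring. Within the data shown here, neither measured step touches this position; the one step that exists, from compound 1 to compound 2, concerns the group on the saturated chain carbon at the amide-type nitrogen, not the ring amine nitrogen, so it tells nothing directly about the new change. Among the measured compounds shown here, with no step bearing on it, the expectation for compound 3 in this assay is a number near that of compound 2, a step of a 1.2-fold higher number from compound 2 to compound 3 (0.08 log units; within the scatter), not clearly beyond the scatter in either direction. Compound 3 is thus estimated at 15 nM, within a range from 5 nM to 50 nM.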

Compound 3, dissociation constant: 3.16 nM
The estimate for compound 3 lay 4.7-fold (0.68 log units) above the measured number, outside the stated range (below it).
By their numbers in this assay, from the lowest: compounds 3 and 1 (each within the scatter of the next); then compound 2.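

In this assay, the ring amine nitrogen of the piperazin-1-yl group proves open to substitution: methylsulfamoyl in place of hydrogen gives a 4.0-fold lower number from compound 2 to compound 3 (0.60 log units; beyond the scatter), a modest change that runs opposite to the near-neutral outcome expected for this position. The earlier compounds shown here varied only the group on the amide-type nitrogen, whereas this result shows that the hydrogen on the ring amine nitrogen is not required for a low number in this assay, and that this second site can also move the read-out beyond the scatter. Nothing measured here accounts for the size or direction of this step.

With a single capping group on this nitrogen, the compounds shown leave open which part of methylsulfamoyl matters, and whether methanesulfonyl, an unsubstituted sulfamoyl, an acetyl or a simple methyl would give a similar number. They also leave open whether the same step would appear with phenyl on the saturated chain carbon at the amide-type nitrogen, as in compound 1, for methylsulfamoyl appears here only alongside cyclopropyl.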